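The source may hold more compounds than are shown below. What is called first, only, known or untested is meant among the compounds shown, and "the series" means these compounds.

Compound 3 `COc1cccc(/C=C/C(=O)c2sc(Nc3ccc(C)cc3)nc2C)c1` is one of three compounds examined in a functional assay on BGC-823 cells (Homo sapiens) for cytotoxicity, read by MTT assay; on this read-out higher numbers stand for weaker inhibition and lower numbers for stronger inhibition. In this assay compound 3 gives > 25000 nM, and that figure is a limit of the assay rather than a number. Compound 1 `COc1cccc(/C=C/C(=O)c2sc(Nc3ccccc3)nc2C)c1` gives 14300 nM in this assay, and compound 2 `Cc1nc(Nc2ccc(Cl)c(Cl)c2)sc1C(=O)/C=C/c1ccc(Cl)cc1` gives 22700 nM. Going by the values given here, the only single change measured is an at least 1.7-fold higher number from compound 1 to compound 3 (0.24 log units; that floor lies within the scatter). Compound 4 `COc1cccc(/C=C/C(=O)c2sc(Nc3ccc(Cl)c(Cl)c3)nc2C)c1` differs from compound 3 by 3,4-dichlorophenyl in place of 4-methylphenyl on a nitrogen on an aromatic ring. Among the compounds with values here, no measured step isolates this exchange; compound 2 carries the same 3,4-dichlorophenyl group on another core, and its value sits near that of compound 1. Compound 4 is therefore expected to give about 20000 nM in this assay, within 8000 nM to 50000 nM, an expected step of an at least 1.2-fold lower number from compound 3 to compound 4 (0.09 log units; that floor lies within the scatter) that stays inside the scatter.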

Compound 4, half-maximal inhibitory concentration: 8350 nM
The estimate for compound 4 lay 2.4-fold (0.38 log units) above the measured number, and the stated range covers the measured number.
By their numbers in this assay, from the lowest: compounds 4, 1 and 2 (each within the scatter of the next, the first and the last beyond it). At a limit, above all of these: compound 3.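

In this assay, 3,4-dichlorophenyl in place of 4-methylphenyl on the nitrogen gives an at least 2.9-fold lower number from compound 3 to compound 4 (0.47 log units; beyond the scatter), so this position responds to the exchange by more than the scatter. That step is only a floor, because compound 3 stands at a limit of the assay: the limit of > 25000 nM in this assay, at which 1 of the 4 values shown sits. Against phenyl the same group gives a 1.7-fold lower number from compound 1 to compound 4 (0.23 log units; within the scatter), which leaves compound 1 and compound 4 indistinguishable, whereas 3-methoxyphenyl in place of 4-chlorophenyl on the chain gives a 2.7-fold lower number from compound 2 to compound 4 (0.43 log units; beyond the scatter).

Going by these compounds, whether one chlorine alone would serve on that nitrogen remains open. So does the outcome with a phenyl ring carrying an amine or a carboxylic acid.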